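Trifluoromethoxy for Trifluoromethyl on a Limit-Bound Series

A few compounds are considered here, and "the series" means these few. Any claim that something is new, unique, unknown or untested is made for them only; others in the source may bear on it.

Compound 2, `Oc1ccccc1-c1cc(-c2ccc(C(F)(F)F)cc2)cc(-c2ccccc2O)n1`, carries two hydroxyphenyl groups and a trifluoromethylphenyl group on a shared core. In a functional assay on DU-145 cells (Homo sapiens) for inhibition (a lower number here means a stronger inhibitor, a higher number a weaker inhibitor), compound 2 gives only a limit of > 50000 nM, not a number. Its neighbours stand the same way. Compound 1, `Oc1ccccc1-c1cc(-c2ccc(F)cc2)cc(-c2ccccc2O)n1`, reaches only the limit of > 50000 nM in this assay. Compound 3, `Oc1ccc(-c2cc(-c3ccc(C(F)(F)F)cc3)cc(-c3ccccc3O)n2)cc1`, likewise reaches only the limit of > 50000 nM in this assay. The first measured step, a step that the two limits leave unreadable from compound 1 to compound 2, cannot be read. The second, a step that the two limits leave unreadable from compound 2 to compound 3, cannot be read either. Within the data shown here, all three values sit at one place, (the limit of > 50000 nM in this assay, at which 3 of the 3 values shown sit), so no measured step yields a direction or a size.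

Compound 4, `Oc1ccccc1-c1cc(-c2ccc(OC(F)(F)F)cc2)cc(-c2ccccc2O)n1`, is the next variation of compound 2: trifluoromethoxy in place of trifluoromethyl on an aromatic carbon. Among the measured compounds shown here, no measured step bears on this change beyond showing that the two changes already made left the limit untouched. The expectation for the step that the limit leaves unreadable from compound 2 to compound 4 is accordingly no readable change beyond the scatter, with the limit again the most likely outcome. Compound 4 is estimated at 60000 nM in this assay, with a range from 15000 nM to 250000 nM.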

Compound 4, half-maximal inhibitory concentration: 20300 nM
For compound 4 the middle estimate is 3.0-fold (0.47 log units) above the measured one; the measured number falls inside the stated range.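

In this assay, among these compounds, compound 4 gives 20300 nM, the only readable number, so the aromatic carbon para to a large group is a place where a single change yields a readable number. Trifluoromethoxy in place of trifluoromethyl gives an at least 2.4-fold lower number from compound 2 to compound 4 (0.39 log units; beyond the scatter), and trifluoromethoxy in place of fluoro gives an at least 2.4-fold lower number from compound 1 to compound 4 (0.39 log units; beyond the scatter), so both changes at this place lead to a weaker limit-free reading beyond the scatter, with the true size of each step bounded on one side only. The starting compounds of both steps stay where the rest of the series stands: the limit of > 50000 nM in this assay, at which 3 of the 4 values shown sit.

The compounds shown leave open whether a longer chain such as ethoxy, or a plain methoxy, at this same place would lower the number further, and whether an amine or a carboxylic acid there would keep any of it. They also leave open whether trifluoromethoxy would give a readable number with 4-hydroxyphenyl in place of 2-hydroxyphenyl, the other change shown in this series.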